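Hydroxy on the acetyl: expected microsomal clearance

This account rests on a few compounds, and the source may have more. Where it says the series, first, only, none or still open, it means among the compounds named here.

Compound 1 `C=CC(=O)Nc1cccc(-n2c(-c3nc(-c4cnn(C5CCN(CC)CC5)c4)cnc3N)nc3ccccc32)c1`: 197 mL.min-1.g-1
Compound 2 `C=CC(=O)Nc1cccc(-n2c(-c3nc(-c4cnn(C5CCN(C(C)=O)CC5)c4)cnc3N)nc3ccccc32)c1`: > 300 mL.min-1.g-1

In an ADME assay on liver for metabolic stability, with Liver microsome (Homo sapiens) as the target, using microsomes (a lower number here means slower removal, a higher number faster removal of the compound), compound 1 gives 197 mL.min-1.g-1. For compound 2 the assay reports only a limit, > 300 mL.min-1.g-1, so compound 2 stands at the edge of what this assay returns; this is the limit of > 300 mL.min-1.g-1 in this assay, at which 1 of the 2 values shown sits. Among the compounds with values here, the single measured step, an at least 1.5-fold higher number from compound 1 to compound 2 (0.18 log units; that floor lies within the scatter), therefore has a floor but no ceiling.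

Compound 3 `C=CC(=O)Nc1cccc(-n2c(-c3nc(-c4cnn(C5CCN(C(=O)CO)CC5)c4)cnc3N)nc3ccccc32)c1` differs from compound 2 by hydroxy in place of hydrogen on a saturated chain carbon bound to a carbonyl carbon. Within the data shown here, no measured step matches this change; the only step at hand concerns the acetyl itself and gives no direction for a hydroxy on its methyl. Compound 2 also offers no number to step from, only a limit. Compound 3 is therefore expected to give a step of an at least 1.0-fold lower number from compound 2 to compound 3 (0.02 log units; that floor lies within the scatter), keeping it near that limit, with a fair chance that the assay again returns only a limit. The estimate for compound 3 is 280 mL.min-1.g-1, in the range 120 mL.min-1.g-1 to 600 mL.min-1.g-1.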

Compound 3, intrinsic clearance in microsomes in the Liver microsome assay: > 300 mL.min-1.g-1
Compound 3: a limit, no number; the forecaster's own chance of this, stated with the estimate: 50%; at least 1.0-fold (0.02 log units) between middle value and limit.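

In the Liver microsome assay compound 3 also returns only a limit, so hydroxy in place of hydrogen on the acetyl leaves the read-out at the edge of the assay: the limit of > 300 mL.min-1.g-1 in the Liver microsome assay, at which 2 of the 3 values shown sit.

With (hydroxymethyl)carbonyl in place of ethyl on the amine nitrogen in the ring, the result is an at least 1.5-fold higher number from compound 1 to compound 3 (0.18 log units; that floor lies within the scatter), so this second acyl group likewise gives only a floor, and one that lies within the scatter. The steps from compound 2 to compound 3 cannot be read in either assay. In a physicochemical assay for solubility, at pH 7.4 (a lower number here means a less soluble compound, a higher number a more soluble compound), compound 2 gives only a limit, < 10000 nM. In the physicochemical assay compound 3 also gives only a limit, < 10000 nM. Neither compound has a number there: the limit of < 10000 nM in the physicochemical assay, at which 2 of the 2 values shown sit.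

Going by these compounds, whether hydroxy on the acetyl shifts clearance at all remains open, as does its effect on solubility. Also open, on these data alone, is whether an amine or a carboxylic acid on that saturated chain carbon bound to a carbonyl carbon, or a longer chain there, would bring a value back inside the range of the assay.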